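Carbamate with 2,2,2-Trifluoroethoxy in Place of 4-Bromophenyl

The source may hold more compounds than are shown below. What is called first, only, known or untested is meant among the compounds shown, and "the series" means these compounds.

Compound 1, `CN(C)c1cc2[nH]c(C3CCCCC3)nc2cc1NC(=O)c1ccco1`, in an ADME assay on Vero cells (Chlorocebus sabaeus) for cytotoxicity, read by resazurin assay, with a stated time of 3 days (on this read-out higher numbers stand for weaker inhibition and lower numbers for stronger inhibition), gives > 100 ug/mL, which is a limit of the assay and not a number.
Compound 2, `CCCCOC(=O)Nc1cc2nc(C3CCCCC3)[nH]c2cc1N(C)C`, in this assay gives > 100 ug/mL, again a limit of the assay.
Compound 3, `CN(C)c1cc2[nH]c(C3CCCCC3)nc2cc1NC(=O)c1ccc(Br)cc1`, in this assay gives > 100 ug/mL, again a limit of the assay.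

Compound 3 therefore stands at the limit of > 100 ug/mL in this assay, at which 3 of the 3 values shown sit, and no number separates it from compound 1 or compound 2. Compound 4, `CN(C)c1cc2[nH]c(C3CCCCC3)nc2cc1NC(=O)OCC(F)(F)F`, differs from compound 3 by 2,2,2-trifluoroethoxy in place of 4-bromophenyl on a carbonyl carbon. The steps that touch the same carbonyl carbon are a step that the two limits leave unreadable from compound 1 to compound 3 and a step that the two limits leave unreadable from compound 2 to compound 3, and also a step that the two limits leave unreadable from compound 1 to compound 2; none of them yields a readable size, because each of the three compounds sits at the limit of > 100 ug/mL in this assay, at which 3 of the 3 values shown sit. With three exchanges on this carbonyl carbon all leaving the read-out at the limit, the expectation for compound 4 is that a step that the limit leaves unreadable from compound 3 to compound 4 will again not be readable, with no step beyond the scatter expected. Compound 4 is thus estimated at 150 ug/mL, within a range from 50 ug/mL to 500 ug/mL, most likely reported only as a limit.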

Compound 4, half-maximal inhibitory concentration: > 100 ug/mL
Compound 4: no number, only a limit (the forecaster's own chance of this, stated with the estimate: 85%); the middle value lies beyond the limit too.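

Among these compounds, compound 4 joins compound 1, compound 2 and compound 3 at a limit of the assay, and so no step from any of them to compound 4 can be read: the limit of > 100 ug/mL in this assay, at which 4 of the 4 values shown sit.

The compounds shown leave open how far each lies beyond that limit in this assay and whether any exchange on this carbonyl carbon alters the read-out.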